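Replacing the thiophene ester with a methylphenyl ester

The compounds below may be only part of what the source reports. "The series", "measured", "known", "first", "only" and "open" are said of these compounds alone.

Compound 1 `Cc1ccccc1C(=O)OC(CCN(C)C)c1ccc(Cl)cc1`: 1700 nM
Compound 2 `Cc1ccsc1C(=O)OC(CCN(C)C)c1ccc(Cl)cc1`: 2510 nM
Compound 3 `Cc1c(Cl)cccc1C(=O)OC(CCN(C)C)c1ccc(Cl)cc1`: 1120 nM

In an assay on NIH3T3 cells with Urotensin-2 receptor (Homo sapiens) as the target (a higher number here means that more compound is needed for the effect, a lower number that less compound is needed), compound 2 gives the highest of the three numbers, but the step of a 1.5-fold higher number from compound 1 to compound 2 (0.17 log units; within the scatter) lies within the scatter, while the step of a 2.2-fold lower number from compound 2 to compound 3 (0.35 log units; beyond the scatter) is beyond it, so only compound 3 is clearly set apart from compound 2. Compound 4 `Cc1ccc(C(=O)OC(CCN(C)C)c2ccc(Cl)cc2)cc1` differs from compound 2 in one place: 4-methylphenyl in place of 3-methylthiophen-2-yl on a carbonyl carbon. The two measured steps that exchange the thiophene for a methylphenyl group, a 1.5-fold higher number from compound 1 to compound 2 (0.17 log units; within the scatter) and a 2.2-fold lower number from compound 2 to compound 3 (0.35 log units; beyond the scatter), both point to a modest lowering of the number when the thiophene leaves. The step from compound 2 to compound 4 is therefore expected to be a 1.7-fold lower number from compound 2 to compound 4 (0.22 log units; within the scatter). Compound 4 is estimated to give 1500 nM in this assay, within a range from 700 nM to 3500 nM.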

Compound 4, half-maximal effective concentration: 2750 nM
Estimate against measurement, compound 4: 1.8-fold (0.26 log units) below; low and high end bracket the measured number.
By their numbers in this assay, from the lowest: compounds 3, 1, 2 and 4 (each within the scatter of the next, the first and the last beyond it).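

Exchanging 3-methylthiophen-2-yl for 4-methylphenyl on this carbonyl carbon does not separate the two esters (a 1.1-fold higher number from compound 2 to compound 4 (0.04 log units; within the scatter)). Among the compounds shown here, compound 4 is likewise not separated from the 2-methylphenyl ester (a 1.6-fold higher number from compound 1 to compound 4 (0.21 log units; within the scatter)), but it is separated from the 3-chloro-2-methylphenyl ester (a 2.5-fold higher number from compound 3 to compound 4 (0.39 log units; beyond the scatter)), the only one of these steps beyond the scatter. No measurement at hand offers a reason for this.

Still open, going by these compounds, is how a phenyl ring carrying an amine or a carboxylic acid in place of the methyl group would compare with compound 4.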